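The source may report more compounds than this note shows. Statements on the series, on what has been measured and on what is new or still open speak of the compounds shown alone.

Measured compounds:
Compound 1 `Cc1nn(-c2cccc(CN)c2)c2c(F)c(-c3ccc(N4CCCCC4=O)cc3)ccc12`: 1900 nM
Compound 2 `CN(C)Cc1nccn1-c1ccc(-c2ccc3c(C(N)=O)nn(-c4ccc5onc(N)c5c4)c3c2F)c(F)c1`: > 10000 nM

Both were tested in an assay on isolated protein for inhibition of Trypsin (Homo sapiens); on this read-out higher numbers stand for weaker inhibition and lower numbers for stronger inhibition. Compound 1 gives a number, 1900 nM. For compound 2 this assay reports only a limit, > 10000 nM, so its inhibition constant is known only as a bound and not as a value. Compound 2 thus stands at the edge of what this assay can record, and (the limit of > 10000 nM in this assay, at which 1 of the 2 values shown sits).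

The unmeasured compound is compound 3 `CN(C)Cc1ccncc1-c1ccc(-c2ccc3c(C(N)=O)nn(-c4ccc5onc(N)c5c4)c3c2F)c(F)c1`. It differs from compound 2 in one place: 4-((dimethylamino)methyl)pyridin-3-yl in place of 2-((dimethylamino)methyl)-1H-imidazol-1-yl on an aromatic carbon. Among the compounds with values here, no step between two measured compounds in this set shows what this kind of change does, so the expectation rests on where compound 2 stands alone. Compound 2 already sits at > 10000 nM, a limit of this assay. Compound 3 is therefore expected to stay weak as well, and the step from compound 2 to compound 3 is estimated as a step that the limit leaves unreadable from compound 2 to compound 3, which means no change beyond the scatter is expected. Compound 3 is estimated at 15000 nM in this assay, within a range from 3000 nM to 80000 nM, with a good chance that the assay again reports only a limit.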

Compound 3, inhibition constant: > 10000 nM
Compound 3 ended at the assay's limit; the forecaster's own chance of this, stated with the estimate: 70%; the middle value is on the limit's open side.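

Compound 2 and compound 3 both end at a limit in this assay rather than at a number, so no step between them can be read: the limit of > 10000 nM in this assay, at which 2 of the 3 values shown sit.

The compounds shown leave open how far either one lies past that limit, and what 4-((dimethylamino)methyl)pyridin-3-yl in place of 2-((dimethylamino)methyl)-1H-imidazol-1-yl does in this assay.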